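The source may report more compounds than this note shows. Statements on the series, on what has been measured and on what is new or still open speak of the compounds shown alone.

Compound 1, `COc1ccc(/C=C/C(=O)c2ccccc2-c2ccc(OC)c(OC)c2)cc1`, is the reference point of this small set. In a functional assay on MCF7 cells (Homo sapiens) for antiproliferative activity, read by sulforhodamine B assay, with a stated time of 48 h (on this read-out lower numbers stand for stronger inhibition and higher numbers for weaker inhibition), compound 1 gives 1100 nM. Compound 2, `COc1ccc(/C=C/C(=O)c2ccccc2-c2ccc(OC)c(OC)c2)cc1OC`, carries one more group on the same core: methoxy in place of hydrogen on an aromatic carbon. In this assay compound 2 gives 4900 nM, so the change produced a 4.5-fold higher number from compound 1 to compound 2 (0.65 log units; beyond the scatter).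

Compound 3, `COc1ccc(C(=O)/C=C/c2ccccc2-c2ccc(F)cc2)cc1`, belongs to a second core; how its core differs from that of compound 1 is not broken down here. In this assay compound 3 gives 8800 nM, which is the highest of the three numbers, within the scatter of compound 2 and beyond the scatter from compound 1.

Compound 4, `COc1ccc(C(=O)/C=C/c2ccccc2-c2ccc(F)cc2)cc1OC`, has not yet been measured. It differs from compound 3 in exactly the way compound 2 differs from compound 1: methoxy in place of hydrogen on an aromatic carbon. The place where the group enters is described in the same words for both pairs, so the change is the same one, made in the pair compound 1 and compound 2 and again in the pair compound 3 and compound 4. Among the compounds with values here, the only measured instance of this change is the step of a 4.5-fold higher number from compound 1 to compound 2 (0.65 log units; beyond the scatter), and that step, carried over to the second core, is the basis for the expectation. Compound 4 is therefore expected to give a higher number than compound 3 in this assay, with an expected step of a 3.4-fold higher number from compound 3 to compound 4 (0.53 log units; beyond the scatter). The estimate for compound 4 is 30000 nM, expected to fall between 12000 nM and 80000 nM.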

Compound 4, half-maximal inhibitory concentration: 7100 nM
Beside the measured number, compound 4's estimate is 4.2-fold (0.63 log units) above it, and the stated range ends above it.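

In this assay, placing the methoxy group on the core of compound 3 gave a 1.2-fold lower number from compound 3 to compound 4 (0.09 log units; within the scatter), so this pair cannot be told apart on this read-out, whereas the same change on the core of compound 1 gave a 4.5-fold higher number from compound 1 to compound 2 (0.65 log units; beyond the scatter). Within the data shown here, the effect seen on the first core therefore did not carry over to the second, and the two steps differ: the same change on two cores in this assay, a 4.5-fold higher number (0.65 log units; beyond the scatter) from compound 1 to compound 2 and a 1.2-fold lower number (0.09 log units; within the scatter) from compound 3 to compound 4, 5.5-fold (0.74 log units) apart, beyond the scatter of two such steps This does not show why they differ, as the two cores are not broken down here into single changes, and with only one pair on each core it gives no rule for any further core.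

The compounds shown leave open whether a hydroxy group, a chlorine or an amine entering at the same place, ortho to a methoxy group, would also give different steps on the two cores. Among these compounds, they also leave open which part of the difference between the two cores matters, including whether the fluorine carried by compound 3 and compound 4 plays any part, as no compound pairs that atom with the core of compound 1.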